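Chloro in place of hydrogen on compound 3

A few compounds are considered here, and "the series" means these few. Any claim that something is new, unique, unknown or untested is made for them only; others in the source may bear on it.

Measured in an ADME assay on HepG2 cells (Homo sapiens) for cytotoxicity, with a stated time of 72 h; a lower number here means that less compound is needed, a higher number that more compound is needed for the effect:
compound 1 `CSc1ccc(NC(=O)Nc2cc(C)nc3ccccc23)cc1`: 16000 nM
compound 2 `Cc1cc(NC(=O)Nc2cccc(F)c2)c2ccccc2n1`: > 25000 nM (a limit)
compound 3 `Cc1cc(NC(=O)Nc2ccc(Cl)cc2)c2ccccc2n1`: > 25000 nM (a limit)

Compound 3 gives > 25000 nM, which is a limit and not a number. Compound 2 gives > 25000 nM, also a limit. The series therefore stands largely at the limit of > 25000 nM in this assay, at which 2 of the 3 values shown sit. Only compound 1 gives a number, 16000 nM.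

Compound 4 `Cc1cc(NC(=O)Nc2ccc(Cl)cc2Cl)c2ccccc2n1` differs from compound 3 by chloro in place of hydrogen on an aromatic carbon. Among the measured compounds shown here, no measured step places a chloro on a carbon that carried hydrogen, so two steps bear on it only indirectly. Chloro in place of methylsulfanyl gives an at least 1.5-fold higher number from compound 1 to compound 3 (0.19 log units; that floor lies within the scatter). 4-Chlorophenyl in place of 3-fluorophenyl gives a step that the two limits leave unreadable from compound 2 to compound 3. Neither sizes the new change, so only a small step to a lower number is expected in this assay, and a further limit is about as likely. The expected change is an at least 1.2-fold lower number from compound 3 to compound 4 (0.09 log units; that floor lies within the scatter). For compound 4 the estimated value is 20000 nM, with an expected range from 9000 nM to 45000 nM.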

Compound 4, half-maximal effective concentration: 16000 nM
Beside the measured number, compound 4's estimate is 1.3-fold (0.10 log units) above it; measured number inside the range.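

In this assay, chloro in place of hydrogen on the aromatic carbon ortho to a large group and meta to a chloro group is the only change shown at this position, and it gives an at least 1.5-fold lower number from compound 3 to compound 4 (0.19 log units; that floor lies within the scatter). Compound 3 gives > 25000 nM, which is a limit. Compound 4 gives a measured number, 16000 nM. This change therefore yields a value rather than a further limit, but the series still sits largely at the limit: the limit of > 25000 nM in this assay, at which 2 of the 4 values shown sit.

On these data alone, the true size of the step remains open, and the readable floor does not show that it exceeds the scatter. Also open, as far as these compounds go, is whether an amine, a methoxy group or a carboxylic acid on this aromatic carbon would give a number or a limit in this assay.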